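A few compounds are considered here, and "the series" means these few. Any claim that something is new, unique, unknown or untested is made for them only; others in the source may bear on it.

Measured compounds:
compound 1, `Cc1ncc([N+](=O)[O-])n1CC(O)CSC(=S)N1CCN(c2ccccn2)CC1`: 2970000 nM
compound 2, `Cc1ncc([N+](=O)[O-])n1CC(O)CSC(=S)N1CCN(c2ncccn2)CC1`: 2040000 nM
compound 3, `Cc1ncc([N+](=O)[O-])n1CC(O)CN1CCN(c2ccccn2)CC1`: 1830000 nM

All three were tested in a toxicity assay on HeLa cells (Homo sapiens) for cytotoxicity, read by MTT assay, with a stated time of 24 h (on this read-out higher numbers stand for weaker inhibition and lower numbers for stronger inhibition), and their numbers lie close to one another. Compound 1 and compound 2 share a core and differ only in pyrimidin-2-yl in place of pyridin-2-yl on an amine nitrogen in a ring; this change produced a 1.5-fold lower number from compound 1 to compound 2 (0.16 log units; within the scatter). Compound 3 stands on a different core, and the difference between the two cores is not broken down here, so of compound 1 and compound 3 one can only say that their two values sit within the usual scatter of each other.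

Compound 4 `Cc1ncc([N+](=O)[O-])n1CC(O)CN1CCN(c2ncccn2)CC1` has not yet been measured in this assay. Going by the values given here, it differs from compound 3 by pyrimidin-2-yl in place of pyridin-2-yl on an amine nitrogen in a ring, the same change, at the same place, as the one from compound 1 to compound 2. Among the compounds with values here, the only guide is that earlier step, which stayed within the scatter. Compound 4 is therefore expected to show a 1.3-fold lower number from compound 3 to compound 4 (0.12 log units; within the scatter), a step of about the same size as a 1.5-fold lower number from compound 1 to compound 2 (0.16 log units; within the scatter). The estimate for compound 4 in this assay is 1400000 nM, expected to fall between 700000 nM and 2900000 nM.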

Compound 4, half-maximal inhibitory concentration: 3930000 nM
Compound 4: the middle estimate sits 2.8-fold (0.45 log units) below what was measured; measured number above the stated range.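

On the core of compound 3, pyrimidin-2-yl in place of pyridin-2-yl on an amine nitrogen in a ring gave a 2.1-fold higher number from compound 3 to compound 4 (0.33 log units; beyond the scatter) in this assay, a modest step. Set beside the earlier step, this shows that the change did not carry over from the core of compound 1 to the core of compound 3 with the same outcome: the same change on two cores in this assay, a 1.5-fold lower number (0.16 log units; within the scatter) from compound 1 to compound 2 and a 2.1-fold higher number (0.33 log units; beyond the scatter) from compound 3 to compound 4, 3.1-fold (0.50 log units) apart, beyond the scatter of two such steps. Going by these compounds alone, the comparison rests on only two pairs, and since the earlier step stayed within the scatter, the firm finding is the gap between the two steps; it does not show what in the two cores sets them apart.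

The compounds shown leave open how the same change would behave on any third core in this series. They also leave open whether a phenyl group or a pyrazin-2-yl group on that amine nitrogen would follow compound 3 or compound 4 on either core.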